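The compounds below may be only part of what the source reports. "The series", "measured", "known", "first", "only" and "open" are said of these compounds alone.

Compound 1, `Cc1n[nH]c(C(=O)O)c1Cc1ccc(C(F)(F)F)cc1`, gives 9% in an assay on isolated protein for inhibition of 2-Hydroxyacid oxidase 2 (Homo sapiens), tested at 1 uM; on this read-out higher numbers stand for a stronger effect at the one concentration tested and lower numbers for a weaker effect. Compound 2, `Cc1n[nH]c(C(=O)O)c1Cc1ccc(Oc2ccccc2)cc1`, gives 10% in this assay. Compound 3, `Cc1n[nH]c(C(=O)O)c1Cc1ccccc1C(F)(F)F`, gives 13% in this assay.

Compound 2 differs from compound 1 by phenoxy in place of trifluoromethyl on an aromatic carbon and the measured step is a number 1 percentage points higher from compound 1 to compound 2 (within the scatter). Compound 3 and compound 1 are built from the same atoms joined differently; the difference between the two cores is not broken down here. Compound 4, `Cc1n[nH]c(C(=O)O)c1Cc1ccccc1Oc1ccccc1`, has not yet been measured. It differs from compound 3 by phenoxy in place of trifluoromethyl on an aromatic carbon. The two places are not the same word for word: in compound 2 the phenoxy stands para to a large group, in compound 4 ortho to a large group, so this is the same kind of change, not the same one. The step of a number 1 percentage points higher from compound 1 to compound 2 (within the scatter) lay within the scatter. On the core of compound 3 a step of similar size is expected, a number 1 percentage points higher from compound 3 to compound 4 (within the scatter), resting on that earlier step. Compound 4 is therefore estimated at 14%, between 4% and 24%.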

Compound 4, a percentage reported as inhibition, at one concentration (the size of the read-out at that concentration, not a potency): 9%
The estimate for compound 4 lay 5 percentage points above the measured number; the range from low to high includes it.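

On the second core the change gives a number 4 percentage points lower from compound 3 to compound 4 (within the scatter). Set beside the earlier step in this assay, it shows no difference between the two cores that can be told apart: the same change on two cores in this assay, a number 1 percentage points higher (within the scatter) from compound 1 to compound 2 and a number 4 percentage points lower (within the scatter) from compound 3 to compound 4, 5 percentage points apart, within the scatter of two such steps. This does not show that the change acts alike on both cores, for neither step stands clear of the scatter, so there is no measured effect to carry from one core to the other.

The compounds shown leave open what an amine or a nitrile in place of trifluoromethyl would give on either core. They also leave open whether an amide in place of the carboxylic acid of the shared core would move the read-out.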